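Swapping chloro for bromo on two related triazole-thiol and thiadiazole cores

The source may hold more compounds than are shown below. What is called first, only, known or untested is meant among the compounds shown, and "the series" means these compounds.

Of the compounds shown here, three have been tested in a functional assay on the whole organism (strain Wistar) for inhibition, with Rattus norvegicus as the target, read by paw edema, with a stated time of 3 h, at a dose of 10 mg/kg by the oral route; a higher number here means more inhibition at the dose given (going by the name of the read-out), a lower number less inhibition. Compound 1, `Sc1nnc(COc2ccc(-c3ccccc3)cc2)n1-c1ccc(Cl)cc1`, gives 15.9%. Compound 2, `Sc1nnc(COc2ccc(-c3ccccc3)cc2)n1-c1ccc(Br)cc1`, differs from compound 1 by bromo in place of chloro on an aromatic carbon, and compound 2 gives 31.8%, a change of a number 15.9 percentage points higher from compound 1 to compound 2 (beyond the scatter). Compound 3, `Clc1ccc(Nc2nnc(COc3ccc(-c4ccccc4)cc3)s2)cc1`, has the same atoms as compound 1 joined in a different way; the difference between the two cores is not broken down here. In this assay compound 3 gives 52.3%, the highest of the three numbers, and its distance from compound 2 and from compound 1 lies beyond the usual scatter in each case.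

Compound 4, `Brc1ccc(Nc2nnc(COc3ccc(-c4ccccc4)cc3)s2)cc1`, has not been measured. It differs from compound 3 by bromo in place of chloro on an aromatic carbon. The place of the change is described in the same words as for the pair of compound 1 and compound 2, so this is the same change, applied here to the core of compound 3, where the ring carrying the halogen sits on an amino group rather than directly on the triazole.

Because the same change gave a number 15.9 percentage points higher from compound 1 to compound 2 (beyond the scatter), a comparable gain is expected, although the starting point is already high, so the expected step is a number 11.7 percentage points higher from compound 3 to compound 4 (beyond the scatter). Compound 4 is therefore expected to give about 64% in this assay, with a likely range between 50% and 78%. This rests on a single earlier pair, so the expectation is tentative.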

Compound 4, a percentage reported as inhibition, in the whole organism at one dose (the size of the read-out at that dose, not a potency): 63.6%
Beside the measured number, compound 4's estimate is 0.4 percentage points above it, within the range that was stated.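

In this assay, bromo in place of chloro on the core of compound 3 gave a number 11.3 percentage points higher from compound 3 to compound 4 (beyond the scatter), so the swap that helped on the first core also helped on this second one. Set side by side, the two steps point the same way and cannot be told apart in size, so in this series the change carried over from one core to the other with its gain intact: the same change on two cores in this assay, a number 15.9 percentage points higher (beyond the scatter) from compound 1 to compound 2 and a number 11.3 percentage points higher (beyond the scatter) from compound 3 to compound 4, 4.6 percentage points apart, within the scatter of two such steps

Within the data shown here, this is still only two pairs, with one halogen swap, read at one oral dose and one time point, so it shows neither how the change would act on a third core nor how the compounds compare in potency, and it gives no reason why bromo reads higher than chloro.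

The compounds shown carry only chloro or bromo at this place on the aromatic ring, which leaves open whether the trend would extend to fluoro, iodo, or a different kind of group such as a methoxy group or a carboxylic acid. From the compounds shown here alone, the link between the core and the biphenyl ether part is also the same throughout, so it remains open how a longer chain there would read.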